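Swapping the aryl ring on a tetrabromo-core alcohol

A few compounds are considered here, and "the series" means these few. Any claim that something is new, unique, unknown or untested is made for them only; others in the source may bear on it.

Compound 1 `OC(CCn1nc2c(Br)c(Br)c(Br)c(Br)c2n1)c1cccc(Br)c1` and compound 2 `OC(CCn1nc2c(Br)c(Br)c(Br)c(Br)c2n1)c1ccc(F)cc1` share a core and differ only in the aryl ring. In a functional assay on CCRF-CEM cells (Homo sapiens) for antiproliferative activity, read by MTT assay, with a stated time of 24 h, tested at 12.5 uM (a lower number here means a stronger effect, a higher number a weaker effect of the compound at the concentration tested), compound 1 gives 102%, and compound 2 gives 110%; the step of a number 8 percentage points higher from compound 1 to compound 2 (within the scatter) lies within the scatter, so neither shows a clear effect at this concentration. Compound 2 stands at one end of the two numbers, with compound 1 the only other, and the gap between them is within the scatter.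

Compound 3 `COc1cccc(C(O)CCn2nc3c(Br)c(Br)c(Br)c(Br)c3n2)c1` is not yet measured. It differs from compound 2 as follows: 3-methoxyphenyl in place of 4-fluorophenyl on a saturated chain carbon bound to an oxygen on a saturated carbon and a saturated chain carbon

Among the compounds with values here, the only measured step that bears on this change is the earlier swap of the aryl ring, a number 8 percentage points higher from compound 1 to compound 2 (within the scatter), which stayed within the scatter. Another swap of the same ring is therefore expected to move this assay by no more than the scatter, in no clear direction, giving an expected a number 5 percentage points lower from compound 2 to compound 3 (within the scatter). Compound 3 is estimated at 105%, within 90% to 120%.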

Compound 3, a percentage reported as activity, at one concentration (the size of the read-out at that concentration, not a potency): 110%
Compound 3: the middle estimate sits 5 percentage points below what was measured; the measured number falls inside the stated range.
By their numbers in this assay, from the lowest: compounds 1, 2 and 3 (each within the scatter of the next).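

Putting 3-methoxyphenyl in place of 4-fluorophenyl on this carbon adds a hydrogen-bond acceptor to the aryl group, and this assay records no change at the digits printed from compound 2 to compound 3 (within the scatter). Methoxy in place of bromo on an aromatic carbon, a change the first pair did not cover, gives a number 8 percentage points higher from compound 1 to compound 3 (within the scatter), so the three aryl groups on the shared core do not separate at this concentration. Nothing available here bears on why these numbers sit together.

What the compounds shown leave open is whether a change at this position can move the read-out at all, as all three aryl groups carry no net charge. An amine or a carboxylic acid on the ring, or a longer chain, could help answer that question.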